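The source may hold more compounds than are shown below. What is called first, only, known or untested is meant among the compounds shown, and "the series" means these compounds.

Measured so far in an ADME assay on NCM460 cells (Homo sapiens) for cytotoxicity, read by MTT assay, with a stated time of 72 h; a lower number here means a stronger inhibitor, a higher number a weaker inhibitor:
- compound 1 `COc1ccc(OC)c(NC(=O)c2cccc(/C=C3\CC(=O)N(c4ccccc4)C3=O)c2)c1`: > 100000 nM
- compound 2 `CCc1cccc(NC(=O)c2cccc(/C=C3\CC(=O)N(c4ccc(C)cc4)C3=O)c2)c1`: > 100000 nM
- compound 3 `CCCCNC(=O)c1cccc(/C=C2\CC(=O)N(Cc3ccccc3)C2=O)c1`: > 100000 nM

In this assay compound 1 gives > 100000 nM, which is a limit of the assay and not a number. The same holds for compound 2 and for compound 3, each reported only as a limit, so nothing separates the three on the numbers shown; all that can be said is that they share (the limit of > 100000 nM in this assay, at which 3 of the 3 values shown sit).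

The next compound is compound 4 `O=C(Nc1cccc(F)c1)c1cccc(/C=C2\CC(=O)N(c3ccccc3)C2=O)c1`. Relative to compound 1 the change is 3-fluorophenyl in place of 2,5-dimethoxyphenyl on an amide-type nitrogen, with the rest of the shared core kept as it stands. Within the data shown here, no step between measured compounds is available to scale this change against. Since every measured value sits at the limit of > 100000 nM in this assay, at which 3 of the 3 values shown sit, the expected step in this assay is none beyond the scatter, and the step is expected to read a step that the limit leaves unreadable from compound 1 to compound 4. For compound 4 the estimate is 150000 nM, with a range from 50000 nM to 500000 nM, and the most likely outcome is that the assay again reports only a limit rather than a number.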

Compound 4, half-maximal inhibitory concentration: > 100000 nM
Compound 4: a limit, no number (the forecaster's own chance of this, stated with the estimate: 85%); the middle value is on the limit's open side.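

No step can be read from compound 1 to compound 4, as both stand only as limits. In this assay compound 4 gives > 100000 nM, a limit of the assay and not a number. The compounds shown leave open whether any change on the shared core would give a readable value in this assay, because all share one reading: the limit of > 100000 nM in this assay, at which 4 of the 4 values shown sit.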